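From methyl to tert-butyl on a pair of limits

This account rests on a few compounds, and the source may have more. Where it says the series, first, only, none or still open, it means among the compounds named here.

Compound 2 `Cc1ccc(Oc2c(/C=N/OCc3snnc3C)c(C)nn2C)cc1` was tested in a functional assay on Huh-7 cells (Homo sapiens) for inhibition, read by MTT assay, with a stated time of 48 h; on this read-out higher numbers stand for weaker inhibition and lower numbers for stronger inhibition. In this assay compound 2 gives only a limit, > 50000 nM, and not a number. Its neighbour compound 1 `Cc1nnsc1CO/N=C/c1c(C)nn(C)c1Oc1ccc(F)cc1` carries fluoro where compound 2 carries methyl. In this assay compound 1 likewise gives a limit, > 50000 nM. The step that the two limits leave unreadable from compound 1 to compound 2 cannot be read because both values sit at the limit of > 50000 nM in this assay, at which 2 of the 2 values shown sit. Compound 3 `Cc1nnsc1CO/N=C/c1c(C)nn(C)c1Oc1ccc(C(C)(C)C)cc1` is the next member of the series: tert-butyl in place of methyl on an aromatic carbon. For the measured compounds named here, only one measured step bears on this change, the unreadable one from fluoro to methyl, so nothing yet shows how large a move of this kind is on the read-out. With both known values at the limit, the expectation for compound 3 is a step that the limit leaves unreadable from compound 2 to compound 3 that most likely stays out of sight as well. Compound 3 is estimated at 70000 nM, with a range from 20000 nM to 250000 nM, and will probably be reported again only as a limit.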

Compound 3, half-maximal inhibitory concentration: > 50000 nM
Compound 3: no number, only a limit; the forecaster's own chance of this, stated with the estimate: 85%; the middle value lies beyond the limit too.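

No step can be read between compound 1, compound 2 and compound 3, because all three stop at a limit and give no number: the limit of > 50000 nM in this assay, at which 3 of the 3 values shown sit.

The compounds shown leave open whether fluoro, methyl or tert-butyl on the aromatic carbon makes any difference to inhibition.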